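Swapping the pentylcarbonyl of compound 1 for a phenyl

The source may hold more compounds than are shown below. What is called first, only, known or untested is meant among the compounds shown, and "the series" means these compounds.

The series was tested in a functional assay on HEK293 cells for agonist activity at prostaglandin E2 receptor EP2 subtype (Rattus norvegicus), read by cAMP accumulation; on this read-out lower numbers stand for an effect already at smaller amounts and higher numbers for an effect only at larger amounts of compound. Compound 1 `CCCCCC(=O)c1ccc(CN(CCCCCCC(=O)O)S(C)(=O)=O)cc1` gives 887 nM, the higher of the two numbers available. Compound 3 `CCCCc1ccc(CN(CCCCOCC(=O)O)S(C)(=O)=O)cc1` gives 407 nM, a lower number that lies beyond the scatter. For compound 2 `CCCCc1ccc(CN(CCCOc2cccc(C(=O)O)c2)S(C)(=O)=O)cc1` the entry in this assay reads "not determined" (no result reported), so no result was reported. The untested compound 4 `CS(=O)(=O)N(CCCCCCC(=O)O)Cc1ccc(-c2ccccc2)cc1` differs from compound 1 in one place: phenyl in place of pentylcarbonyl on an aromatic carbon, on an aromatic carbon of a six-membered aromatic ring of carbon only, para to a large group. Going by the values given here, no measured pair shows this change, so the direction is open; a step of modest size is expected, within or just beyond the scatter, slightly downward. The estimate is that the move from compound 1 to compound 4 gives a 1.5-fold lower number from compound 1 to compound 4 (0.17 log units; within the scatter). Compound 4 is expected to give 600 nM, between 150 nM and 2500 nM.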

Compound 4, half-maximal effective concentration: 457 nM
The estimate for compound 4 lay 1.3-fold (0.12 log units) above the measured number, and the stated range covers the measured number.
By their numbers in this assay, from the lowest: compounds 3, 4 and 1 (each within the scatter of the next, the first and the last beyond it).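

At the aromatic carbon para to a large group, phenyl in place of pentylcarbonyl gives a 1.9-fold lower number from compound 1 to compound 4 (0.29 log units; within the scatter) in this assay. The open chain with its carbonyl can therefore give way to a six-membered aromatic ring of carbon only without the number moving beyond the scatter. The data shown offer no explanation for this result.

The compounds shown leave open whether a pyridyl ring or a phenyl carrying a fluorine at this place would keep the number in this range. They also leave open whether phenyl would behave alike on the acid chain of compound 3.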